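Fluoro Gives Way to Methoxy in Compound 3

The compounds below may be only part of what the source reports. "The series", "measured", "known", "first", "only" and "open" are said of these compounds alone.

In an ADME assay on the whole organism (Rattus norvegicus, strain Lewis) for metabolic stability, at a dose of 2 mg/kg by the oral route (on this read-out higher numbers stand for a longer-lived compound and lower numbers for a shorter-lived compound), compound 1 `COc1ccccc1OC[C@@H]1CCc2cc([C@H]3CC[C@](N)(CO)C3)ccc2C1` gives 14 h, while compound 2 `N[C@]1(CO)CC[C@H](c2ccc3c(c2)CC[C@@H](COc2ccc(F)cc2)C3)C1` gives 46 h, the higher of the two numbers. Going by the values given here, only one measured step bears on what follows: a 3.3-fold higher number from compound 1 to compound 2 (0.52 log units; beyond the scatter), with 4-fluorophenyl in place of 2-methoxyphenyl. Compound 3 `COc1ccc(OC[C@@H]2CCc3cc([C@H]4CC[C@](N)(CO)C4)ccc3C2)cc1` differs from compound 2 in one place: methoxy in place of fluoro on an aromatic carbon, para to a large group. The measured step is only a partial guide, since it involves 2-methoxyphenyl and compound 3 carries 4-methoxyphenyl. Among the compounds with values here, still, compound 1, the only measured compound with a methoxy, stands at 14 h, so a modest fall in this assay is expected, of similar or smaller size than the measured step. The expected change is a 2.1-fold lower number from compound 2 to compound 3 (0.32 log units; beyond the scatter). For compound 3 the estimated half-life is 22 h, with an expected range of 9 h to 50 h.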

Compound 3, half-life: < 10 h
Compound 3: only a limit was reported; the forecaster's own chance of this, stated with the estimate: 2%; middle value at least 2.2-fold (0.34 log units) away from the limit.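

Compound 3 shows that this one position, para to a large group, carries much of the result on its own: with the rest of compound 2 unchanged, methoxy in place of fluoro gives an at least 4.6-fold lower number from compound 2 to compound 3 (0.66 log units; beyond the scatter). In this assay compound 3 gives only a limit, not a number, < 10 h. Moving the methoxy on the phenyl ring gives an at least 1.4-fold lower number from compound 1 to compound 3 (0.14 log units; that floor lies within the scatter), so 4-methoxyphenyl and 2-methoxyphenyl cannot be told apart here, and methoxy at either place stays well short of the 4-fluorophenyl of compound 2.

How far the half-life of compound 3 really falls stays open: the limit of < 10 h in this assay, at which 1 of the 3 values shown sits. Nor do the compounds shown tell whether chloro, methyl or a plain unsubstituted phenyl at this position would stand nearer to fluoro or to methoxy.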